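Anilide in place of benzylamide on a shared quinoline-free core

The source may hold more compounds than are shown below. What is called first, only, known or untested is meant among the compounds shown, and "the series" means these compounds.

Of the compounds shown here, three share one core and have been measured in a physicochemical assay for lipophilicity, read by HPLC, in phosphate buffer, measured as chromatographic lipophilicity, at pH 7.4; on this read-out higher numbers stand for higher lipophilicity and lower numbers for lower lipophilicity. Compound 1 `COc1ccc2nc(C)cc(OC(C)(C)C(=O)Nc3cc(C)cc(C)c3)c2c1` gives 6.37 in this assay. Compound 2 `COc1ccc2nc(C)c(NC(=O)C(=O)Nc3cc(C)cc(C)c3)c(O)c2c1` gives 3.76. Compound 3 `COc1ccc2nc(C)cc(OCC(=O)NCc3cc(C)cc(C)c3)c2c1` gives 5.25, which places it second highest of the three: compound 1 lies beyond the scatter above it, and compound 2 lies beyond the scatter below it. No two of these compounds differ in only one place, so no single step between measured values is known.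

Compound 4 `COc1ccc2nc(C)cc(OCC(=O)Nc3cc(C)c(F)c(C)c3)c2c1` has not yet been measured in this assay. It differs from compound 3 in one place: 4-fluoro-3,5-dimethylphenyl in place of 3,5-dimethylbenzyl on an amide-type nitrogen. Because compound 1, whose amide-type nitrogen also carries an aromatic ring directly, gives 6.37, compound 4 is expected to sit closer to compound 1 than compound 3 does. The step of a number 0.65 log units higher from compound 3 to compound 4 (beyond the scatter) is therefore expected to be upward and beyond the scatter. Compound 4 is estimated at 5.9, with a range from 5.3 to 6.5.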

Compound 4, distribution coefficient: 5.5
For compound 4 the middle estimate is 0.40 log units above the measured one; the measured number falls inside the stated range.
By their numbers in this assay, from the lowest: compound 2; then compounds 3 and 4 (each within the scatter of the next); then compound 1.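

In this assay the step of a number 0.25 log units higher from compound 3 to compound 4 (within the scatter) is the only single-place comparison among the compounds shown, and it concerns the group on the amide-type nitrogen. It shows that 4-fluoro-3,5-dimethylphenyl and 3,5-dimethylbenzyl cannot be told apart at this position on this read-out, even though the entering group joins its ring directly to that nitrogen and carries fluorine. Nothing available explains this result.

The exchange alters two features at once, and with no 4-fluoro-3,5-dimethylbenzyl group among the compounds shown, the contribution of the fluorine cannot be separated from that of the change from benzyl to phenyl. From the compounds shown here alone, whether an amine or a carboxylic acid on that aromatic ring would move the number beyond the scatter also remains open.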